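Compound 3 and the Sulfonyl Chain

The source may hold more compounds than are shown below. What is called first, only, known or untested is meant among the compounds shown, and "the series" means these compounds.

In a physicochemical assay for acid dissociation, compound 1 `CCCCS(=O)(=O)c1ccc(O)c(C(=O)Nc2ccc(C(F)(F)F)cc2)c1` gives 6.2. For the measured compounds named here, this places it level with the only other measured compound, since compound 2 `CCCCCCCCS(=O)(=O)c1ccc(O)c(C(=O)Nc2ccc(C(F)(F)F)cc2)c1` gives 6.2. The open question concerns compound 3 `CCCCCCCCCCS(=O)(=O)c1ccc(O)c(C(=O)Nc2ccc(C(F)(F)F)cc2)c1`, which keeps the core of compound 1 and differs from it only in the chain on the sulfonyl group: hexyl in place of hydrogen on a saturated chain carbon, four bonds along the chain from a sulfonyl sulfur. Going by the values given here, one measured step bears on this change, with butyl entering at that same place: no change at the digits printed from compound 1 to compound 2 (within the scatter). Among the compounds with values here, it is a single step, and no measured compound carries hexyl at this place, so the evidence is thin. With compound 2 at 6.2, no shift beyond the scatter is expected in this assay, in either direction. The estimated step is no change at the digits printed from compound 1 to compound 3 (within the scatter). For compound 3 the expected value is 6.2, with an estimated range from 5.9 to 6.5.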

Compound 3, acid dissociation constant: 6.2
Beside the measured number, compound 3's estimate shows no gap at the digits printed; measured number inside the range.
By their numbers in this assay, from the lowest: compounds 1, 2 and 3 (each within the scatter of the next).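

In this assay, the sulfonyl chain now has a second, larger entering group at the same place: hexyl in place of hydrogen on a saturated chain carbon, four bonds along the chain from a sulfonyl sulfur, gives no change at the digits printed from compound 1 to compound 3 (within the scatter). The result also reaches further out along the chain, where ethyl in place of hydrogen on a saturated chain carbon, eight bonds along the chain from a sulfonyl sulfur, gives no change at the digits printed from compound 2 to compound 3 (within the scatter). Where one step stood before, compound 1, compound 2 and compound 3 now form a set of three that stand level, so among these compounds the butyl and hexyl additions do not separate the read-out. No measured information on hand accounts for this result.

The compounds shown carry only unbranched saturated chains on the sulfonyl group, which leaves open whether a longer chain, a branched chain or a chain ending in an amine or a carboxylic acid would also stand level in this assay. They also leave open whether a group in place of the trifluoromethyl, such as a nitrile, would shift the read-out when the chain is held fixed.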